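The compounds below may be only part of what the source reports. "The series", "measured", "known", "first", "only" and "open" are said of these compounds alone.

Measured compounds and their values:

Compound 1 `CN(C)c1ccc(/C=C(\C(=O)c2ccc(Br)cc2)S(=O)(=O)Cc2ccc(F)cc2)cc1` — 50000 nM
Compound 2 `O=C(/C(=C\c1ccccc1O)Sc1ccccc1Br)c1ccc(Br)cc1` — 50000 nM
Compound 3 `O=C(/C(=C\c1ccc(O)c([N+](=O)[O-])c1)SCc1ccccc1Cl)c1ccc(Cl)cc1` — 10000 nM

In a functional assay on DU-145 cells (Homo sapiens) for inhibition, read by trypan blue exclusion, with a stated time of 96 h (a lower number here means a stronger inhibitor of growth, a higher number a weaker inhibitor of growth), compound 1 stands level with compound 2 at the digits shown, and the two of them are the highest numbers of the three. Compound 3 gives the lowest number, a gap from compound 1 that lies beyond the scatter. Compound 4 `Cc1ccc(C)c(/C=C(\C(=O)c2ccc(Br)cc2)S(=O)(=O)Cc2ccc(F)cc2)c1` has not yet been measured in this assay. It differs from compound 1 in one place: 2,5-dimethylphenyl in place of 4-(dimethylamino)phenyl on a double-bonded chain carbon bound to a double-bonded chain carbon. For the measured compounds named here, no measured pair tells how such a change behaves here. The step to compound 4 is therefore expected to be small and not clearly beyond the scatter, estimated as a 1.4-fold lower number from compound 1 to compound 4 (0.15 log units; within the scatter). Compound 4 is therefore expected to give 35000 nM in this assay, with a likely range from 10000 nM to 60000 nM.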

Compound 4, concentration for 50% growth inhibition: 1000 nM
Compound 4: the middle estimate sits 35-fold (1.54 log units) above what was measured; measured number below the stated range.
By their numbers in this assay, from the lowest: compound 4; then compound 3; then compounds 1 and 2 (each within the scatter of the next).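

In this assay, the place on a double-bonded chain carbon bound to a double-bonded chain carbon proves highly sensitive: 2,5-dimethylphenyl in place of 4-(dimethylamino)phenyl gives a 50-fold lower number from compound 1 to compound 4 (1.70 log units; beyond the scatter). For the compounds shown here, the earlier compounds offered no pair differing in one place, so this is the first direct sign that a change here alone can shift growth inhibition. Nothing available explains the step. On these data alone, whether an unsubstituted phenyl or a methoxyphenyl here would match compound 4 stays open, as does whether the step would hold on a core other than that of compound 1.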